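Bromo in Place of Chloro: A Paired Comparison

The compounds below may be only part of what the source reports. "The series", "measured", "known", "first", "only" and "open" are said of these compounds alone.

The study concerns four compounds tested in an assay on tissue (HeLa cells) for inhibition of Indoleamine 2,3-dioxygenase 1 (Homo sapiens), read by spectrophotometry; a higher number here means a weaker inhibitor, a lower number a stronger inhibitor. Compound 1 has the structure `O/N=C(/Nc1ccc(F)c(Cl)c1)c1ccc2occc2c1`, and in this assay compound 1 gives 1800 nM. Compound 2, `O/N=C(/Nc1ccc(F)c(Br)c1)c1ccc2occc2c1`, differs from it by bromo in place of chloro on an aromatic carbon, and compound 2 gives 2600 nM. The step of a 1.4-fold higher number from compound 1 to compound 2 (0.16 log units; within the scatter) is therefore small.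

Compound 3, `COCc1cc2cc(/C(=N\O)Nc3cccc(Cl)c3)ccc2o1`, is built on a different core; the difference between the core of compound 1 and the core of compound 3 is not broken down here. In this assay compound 3 gives 2200 nM, a number that sits close to both compound 1 and compound 2, with no separation beyond the scatter among the three.

Compound 4, `COCc1cc2cc(/C(=N\O)Nc3cccc(Br)c3)ccc2o1`, has not yet been measured. It differs from compound 3 by bromo in place of chloro on an aromatic carbon. Within the data shown here, this is the same kind of change as the one from compound 1 to compound 2, though not the same: in compound 1 the replaced chloro stands ortho to a fluoro group and meta to a large group, whereas in compound 3 it stands only meta to a large group.

Compound 4 is expected to move by a 1.3-fold higher number from compound 3 to compound 4 (0.12 log units; within the scatter), a step estimated to resemble a 1.4-fold higher number from compound 1 to compound 2 (0.16 log units; within the scatter), since that earlier exchange produced only a small change within the scatter. Compound 4 is thus estimated to give about 2900 nM, with a plausible range from 1400 nM to 6000 nM.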

Compound 4, half-maximal inhibitory concentration: 2500 nM
Compound 4: middle estimate off by 1.2-fold (0.06 log units), on the high side; the measured number falls inside the stated range.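

In this assay, bromo in place of chloro on the core of compound 3 gives a 1.1-fold higher number from compound 3 to compound 4 (0.06 log units; within the scatter). Set beside the same exchange on the core of compound 1, the change carries from one core to the other with no difference that can be told apart: the same change on two cores in this assay, a 1.4-fold higher number (0.16 log units; within the scatter) from compound 1 to compound 2 and a 1.1-fold higher number (0.06 log units; within the scatter) from compound 3 to compound 4, 1.3-fold (0.10 log units) apart, within the scatter of two such steps. This shows that the exchange stayed small on both cores, even though compound 1 and compound 2 also carry a fluoro group that compound 3 and compound 4 lack, but it does not show that the two steps are truly equal, and two pairs cannot establish that chloro and bromo would be interchangeable on other cores of the series.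

The compounds shown have only chloro or bromo at the exchanged place, and they leave open how a methyl, a methoxy or an amine there would read in this assay. They also leave open whether iodo in place of bromo, or a carboxylic acid at the same place, would remain as close on both cores as the two halogens do here.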